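Swapping a benzoxazole for a small thiadiazole

The source may report more compounds than this note shows. Statements on the series, on what has been measured and on what is new or still open speak of the compounds shown alone.

Compound 2 `Cc1ccc2oc(SCC(=O)Nc3ccc(-c4nc(-c5ccccc5)c(-c5ccccc5)n4C)cc3)nc2c1`: 22.4 ug/mL
Compound 1 `Cn1c(-c2ccc(NC(=O)CSc3nc4cc(Cl)ccc4o3)cc2)nc(-c2ccccc2)c1-c1ccccc1`: 21.7 ug/mL
Compound 3 `Cn1nnnc1SCC(=O)Nc1ccc(-c2nc(-c3ccccc3)c(-c3ccccc3)n2C)cc1`: 4.5 ug/mL

In a functional assay on MCF7 cells (Homo sapiens) for cytotoxicity, read by MTT assay, with a stated time of 24 h (a higher number here means a weaker inhibitor, a lower number a stronger inhibitor), compound 2 gives the highest number of the three, with compound 1 close by and compound 3 well apart. Compound 4 `Cc1nnc(SCC(=O)Nc2ccc(-c3nc(-c4ccccc4)c(-c4ccccc4)n3C)cc2)s1` differs from compound 2 by 5-methyl-1,3,4-thiadiazol-2-yl in place of 5-methyl-1,3-benzoxazol-2-yl on a sulfur. The step that bears on this is a 5.0-fold lower number from compound 2 to compound 3 (0.70 log units; beyond the scatter), where a small five-membered heteroaryl also replaced the larger benzoxazole; the step of a 4.8-fold lower number from compound 1 to compound 3 (0.68 log units; beyond the scatter) points the same way, while a 1.0-fold higher number from compound 1 to compound 2 (0.01 log units; within the scatter) shows that a methyl or chloro on the benzoxazole hardly matters. A lower number is therefore expected for compound 4, of a size a 2.8-fold lower number from compound 2 to compound 4 (0.45 log units; beyond the scatter). The estimated value for compound 4 in this assay is 8 ug/mL, ranging from 3.5 ug/mL to 18 ug/mL.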

Compound 4, half-maximal inhibitory concentration: 3.2 ug/mL
Compound 4: the middle estimate sits 2.5-fold (0.40 log units) above what was measured; measured number outside the range, below it.
By their numbers in this assay, from the lowest: compounds 4 and 3 (each within the scatter of the next); then compounds 1 and 2 (each within the scatter of the next).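

Putting 5-methyl-1,3,4-thiadiazol-2-yl on this sulfur in place of the benzoxazole gives a 7.0-fold lower number from compound 2 to compound 4 (0.85 log units; beyond the scatter) and a 6.8-fold lower number from compound 1 to compound 4 (0.83 log units; beyond the scatter) as well, so the drop seen with the tetrazole also appears with a second small five-membered ring. The two small rings cannot be told apart, with a 1.4-fold lower number from compound 3 to compound 4 (0.15 log units; within the scatter) here. Nothing measured says why the smaller rings give lower numbers.

Going by these compounds, whether a heteroaryl ring is needed here at all stays open; a plain phenyl ring or a short chain ending in an amine would test that. On these data alone, whether the methyl on the thiadiazole matters is also open.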